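Chalcone series on A549 cells: halogen swap on the ketone ring

The compounds below may be only part of what the source reports. "The series", "measured", "known", "first", "only" and "open" are said of these compounds alone.

Of the compounds shown here, three have been measured in a functional assay on A549 cells (Homo sapiens) for antiproliferative activity, read by MTT assay, with a stated time of 48 h; on this read-out higher numbers stand for weaker inhibition and lower numbers for stronger inhibition. Compound 1 `O=C(/C=C/c1cc(Br)cc(Br)c1Oc1c([N+](=O)[O-])cc(C(F)(F)F)cc1[N+](=O)[O-])c1ccc(F)cc1` gives 120 ug/mL. Compound 3 `O=C(/C=C/c1cc(Br)cc(Br)c1Oc1c([N+](=O)[O-])cc(C(F)(F)F)cc1[N+](=O)[O-])c1ccc(Cl)cc1` gives 19.4 ug/mL. Compound 2 `O=C(/C=C/c1cc(Cl)cc(Cl)c1Oc1c([N+](=O)[O-])cc(C(F)(F)F)cc1[N+](=O)[O-])c1ccc(F)cc1` gives 29.4 ug/mL in this assay. Compound 4 `O=C(/C=C/c1cc(Cl)cc(Cl)c1Oc1c([N+](=O)[O-])cc(C(F)(F)F)cc1[N+](=O)[O-])c1ccc(Cl)cc1` has not yet been measured.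

The difference between the cores of compound 1 and compound 2 is not broken down here. Compound 3 differs from compound 1 by chloro in place of fluoro on an aromatic carbon, and this change produced a 6.2-fold lower number from compound 1 to compound 3 (0.79 log units; beyond the scatter). Compound 4 differs from compound 2 by the same change, (chloro in place of fluoro on an aromatic carbon), so the step in this assay from compound 2 to compound 4 can be read against the one already measured. For the measured compounds named here, compound 2 already sits well below compound 1, and only one measured instance of the change is available, so a somewhat smaller step than a 6.2-fold lower number from compound 1 to compound 3 (0.79 log units; beyond the scatter) seems the safer expectation; the estimated step is a 2.9-fold lower number from compound 2 to compound 4 (0.47 log units; beyond the scatter). Compound 4 is therefore expected at about 10 ug/mL in this assay, plausibly between 4 ug/mL and 25 ug/mL.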

Compound 4, half-maximal inhibitory concentration: 17.2 ug/mL
For compound 4 the middle estimate is 1.7-fold (0.24 log units) below the measured one; measured number inside the range.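

In this assay, chloro in place of fluoro on the core of compound 2 gives a 1.7-fold lower number from compound 2 to compound 4 (0.23 log units; within the scatter), a step that stays within the scatter and so shows no clear gain on this core. The size of the step therefore does not carry over from one core to the other, and the larger step on the core of compound 1 cannot be used as a general value for this change: the same change on two cores in this assay, a 6.2-fold lower number (0.79 log units; beyond the scatter) from compound 1 to compound 3 and a 1.7-fold lower number (0.23 log units; within the scatter) from compound 2 to compound 4, 3.6-fold (0.56 log units) apart, beyond the scatter of two such steps. For the compounds shown here, with only two pairs on two cores, this shows that the step depends on the core in these compounds, but it does not show which feature of the cores is responsible or how the change would behave on any further core.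

Still open, from the compounds shown here alone, is whether an amine or a methoxy group in place of the chloro of the 4-chlorophenyl group would give a step beyond the scatter on either core. Going by these compounds, the contribution of the two nitro groups and the trifluoromethyl group also remains open, as all four compounds carry them unchanged.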